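This account rests on a few compounds, and the source may have more. Where it says the series, first, only, none or still open, it means among the compounds named here.

In a functional assay with Oryctolagus cuniculus as the target (a lower number here means a stronger inhibitor, a higher number a weaker inhibitor), compound 1 `COc1ccc(-c2nc(N=C(N)N)sc2-c2ccc(OC)cc2)cc1` gives 31000 nM. Compound 2 `COc1ccc(-c2nc(/N=C(\N)NC(C)C)sc2-c2ccc(OC)cc2)cc1` gives > 100 nM, which is a limit and not a number. Compound 3 `COc1ccc(-c2nc(C(=O)N(C)C)sc2-c2ccc(OC)cc2)cc1` gives < 100 nM, which is also a limit. Only compound 1 has an exact number, so compound 3 can be placed only by its limit. Compound 4 `COc1ccc(-c2nc(C(=O)N3CCCCC3CCO)sc2-c2ccc(OC)cc2)cc1` keeps the carbonyl of compound 3 but changes the group on it: 2-(2-hydroxyethyl)piperidin-1-yl in place of dimethylamino on a carbonyl carbon. Going by the values given here, the one readable step, an at least 310-fold lower number from compound 1 to compound 3 (2.49 log units; beyond the scatter), introduced the carbonyl group that compound 4 retains. Among the compounds with values here, no measured step changes the group on the carbonyl carbon, so no clear direction is expected. The expected change, a step that the limit leaves unreadable from compound 3 to compound 4, is estimated to stay within the scatter. For compound 4 the estimated value is 60 nM, with an expected range from 6 nM to 600 nM.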

Compound 4, half-maximal inhibitory concentration: 45 nM
The estimate for compound 4 lay 1.3-fold (0.12 log units) above the measured number, within the range that was stated.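

The step between compound 3 and compound 4 cannot be read, because compound 3 carries only a limit and not a number: the limit of < 100 nM in this assay, at which 1 of the 4 values shown sits. On these data alone, whether 2-(2-hydroxyethyl)piperidin-1-yl gives a lower or higher number than dimethylamino on the carbonyl carbon remains open.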